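Replacing the cyclopentyl on the amide nitrogen with 2-hydroxyethyl

The compounds below may be only part of what the source reports. "The series", "measured", "known", "first", "only" and "open" are said of these compounds alone.

Measured so far:
compound 1, `CCNC(=O)CC1CCc2cc(OC)c(OC)cc21`: 23.6%
compound 2, `CCCCCNC(=O)CC1CCc2cc(OC)c(OC)cc21`: 71.7%
compound 3, `COc1cc2c(cc1OC)C(CC(=O)NC1CCCC1)CC2`: 37%

The three compounds share one core and differ only in the group carried on the amide-type nitrogen. In a functional assay on the whole organism (strain Swiss albino) for inhibition, with Mus musculus as the target, in the writhing test, with stated times of 60 min and 15 min, at a dose of 100 mg/kg by the oral route (a lower number here means less inhibition, a higher number more inhibition at the dose given (going by the name of the read-out)), compound 3 gives 37% and stands second highest of the three: the nearest is compound 1, with a number 13.4 percentage points higher from compound 1 to compound 3 (beyond the scatter), and the furthest is compound 2, with a number 34.7 percentage points lower from compound 2 to compound 3 (beyond the scatter). Compound 4, `COc1cc2c(cc1OC)C(CC(=O)NCCO)CC2`, has not yet been measured. Its difference from compound 3 is 2-hydroxyethyl in place of cyclopentyl on an amide-type nitrogen.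

For the measured compounds named here, no measured step swaps a ring for a hydroxyl-bearing chain, so only the two steps that change the group on the amide nitrogen bear on this one. They show that the group on that nitrogen matters: the step from ethyl to cyclopentyl was modest, that from pentyl to cyclopentyl large. The group entering in compound 4 is small, closer in size to the ethyl of compound 1 than to the pentyl of compound 2. Compound 4 is therefore expected to sit somewhat below compound 3 in this assay, with a number 9 percentage points lower from compound 3 to compound 4 (within the scatter), and the estimate for compound 4 is 28%, ranging from 10% to 48%.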

Compound 4, a percentage reported as inhibition, in the whole organism at one dose (the size of the read-out at that dose, not a potency): 29.8%
Compound 4: middle estimate off by 1.8 percentage points, on the low side, within the range that was stated.
By their numbers in this assay, from the lowest: compounds 1, 4 and 3 (each within the scatter of the next, the first and the last beyond it); then compound 2.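

In this assay, 2-hydroxyethyl in place of cyclopentyl on the amide-type nitrogen gives a number 7.2 percentage points lower from compound 3 to compound 4 (within the scatter), and hydroxy in place of hydrogen on the saturated chain carbon gives a number 6.2 percentage points higher from compound 1 to compound 4 (within the scatter), so a hydroxyl-bearing chain with no ring cannot be told apart from either the ring of compound 3 or the plain ethyl of compound 1. Hydroxy in place of propyl on that same carbon gives a number 41.9 percentage points lower from compound 2 to compound 4 (beyond the scatter), which leaves the pentyl of compound 2 as the only group here whose number is separated from all the others by more than the scatter, while the remaining three groups differ in ring, chain length and hydroxyl without a clear change between neighbouring values. No measurement shown here accounts for these numbers.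

A longer chain such as hexyl or octyl on the same nitrogen would show whether the number keeps rising beyond pentyl. A 5-hydroxypentyl group would show whether the hydroxyl can be carried on the longer chain, and 2-aminoethyl or a carboxylic acid on the short chain would test other end groups.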